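Isatin-derived series: thiophene swap on the E and Z isomers

This account rests on a few compounds, and the source may have more. Where it says the series, first, only, none or still open, it means among the compounds named here.

Three compounds of a shared core carry a bromoacrylamide and an exocyclic double bond bearing a thiophene, and were tested in a functional assay on Jurkat cells (Homo sapiens) for antiproliferative activity, read by MTT assay, with a stated time of 72 h; a higher number here means a weaker inhibitor, a lower number a stronger inhibitor. Compound 2 `C=C(Br)C(=O)Nc1ccc2c(c1)/C(=C\c1ccsc1)C(=O)N2` gives 56 nM. Compound 1 `C=C(Br)C(=O)Nc1ccc2c(c1)/C(=C\c1ccc(C)s1)C(=O)N2` gives 150 nM, and compound 3 `C=C(Br)C(=O)Nc1ccc2c(c1)/C(=C/c1ccsc1)C(=O)N2` gives 190 nM.

Two single changes link them. The change 5-methylthiophen-2-yl in place of thiophen-3-yl on a double-bonded chain carbon bound to a double-bonded ring carbon gives a 2.7-fold higher number from compound 2 to compound 1 (0.43 log units; beyond the scatter). The change the two compounds have the same atoms and bonds and differ only in configuration as drawn: 1 of 1 stereo elements differ; a double bond is drawn E in compound 2 and Z in compound 3 gives a 3.4-fold higher number from compound 2 to compound 3 (0.53 log units; beyond the scatter); the only thing separating these two compounds is the fact that compounds 2 and 3 differ only in the configuration as drawn. Among the three, compound 3 sits at the high end, but its gap to compound 1 is within the scatter, so no order between them is claimed.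

Compound 4 `C=C(Br)C(=O)Nc1ccc2c(c1)/C(=C/c1ccc(C)s1)C(=O)N2` is not yet measured in this assay. It differs from compound 3 by 5-methylthiophen-2-yl in place of thiophen-3-yl on a double-bonded chain carbon bound to a double-bonded ring carbon, which is the same change as that from compound 2 to compound 1, both place lines reading the same word for word; the two cores differ only by the configuration given under (the two compounds have the same atoms and bonds and differ only in configuration as drawn: 1 of 1 stereo elements differ; a double bond is drawn E in compound 2 and Z in compound 3). The change occurs twice in the set, measured once. Carrying the measured step over, the estimated step of a 2.4-fold higher number from compound 3 to compound 4 (0.37 log units; beyond the scatter) is expected to match a 2.7-fold higher number from compound 2 to compound 1 (0.43 log units; beyond the scatter) in direction and roughly in size, resting on compound 1 at 150 nM against compound 2 at 56 nM. On these data alone, whether the Z core responds to the methylthiophene in the same way is untested, so the range is kept wide. Compound 4 is expected to give 450 nM, estimated between 180 nM and 1200 nM.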

Compound 4, half-maximal inhibitory concentration: 360 nM
Compound 4: middle estimate off by 1.3-fold (0.10 log units), on the high side; the range from low to high includes it.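

In this assay, the swap to 5-methylthiophen-2-yl on the core of compound 3 gives a 1.9-fold higher number from compound 3 to compound 4 (0.28 log units; within the scatter), and this step agrees with the one measured on the other double-bond configuration: the same change on two cores in this assay, a 2.7-fold higher number (0.43 log units; beyond the scatter) from compound 2 to compound 1 and a 1.9-fold higher number (0.28 log units; within the scatter) from compound 3 to compound 4, 1.4-fold (0.15 log units) apart, within the scatter of two such steps. This shows that the change carries over between these two cores without a detectable difference, but it does not show an identical size on both, and the step on the core of compound 3 alone supports no order between compound 3 and compound 4. The configuration step also recurs with the new group in place, at a 2.4-fold higher number from compound 1 to compound 4 (0.38 log units; beyond the scatter) beside a 3.4-fold higher number from compound 2 to compound 3 (0.53 log units; beyond the scatter), so the higher number on the Z side is seen with both thiophene groups, and in the newer pair only the drawn geometry separates the two compounds: the fact that compounds 1 and 4 differ only in the configuration as drawn.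

The swap alters both the methyl group and the point of attachment of the thiophene, so the compounds shown leave open which of the two carries the step, a question that a plain thiophen-2-yl on each core would address. They also leave open whether the step holds for a different ring in that place, such as a phenyl or a pyridine, or for a thiophene bearing an amine or a carboxylic acid.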